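This account rests on a few compounds, and the source may have more. Where it says the series, first, only, none or still open, it means among the compounds named here.

Of the compounds shown here, two have been measured in an assay on Cortex for displacement of a labelled ligand from Voltage-dependent L-type calcium channel subunit alpha-1D (Rattus norvegicus); a higher number here means a weaker inhibitor, a lower number a stronger inhibitor. Compound 1 `COC(=O)C1=C(C)N=C(C)/C(=C(\O)OC)C1c1cccc([N+](=O)[O-])c1` gives 2.6 nM in this assay, while compound 2 `COC(=O)C1=C(C)N=C(C)/C(=C(/O)OC)C1c1cccc(OCc2nonc2C)c1`, which carries the 4-methyl-1,2,5-oxadiazol-3-yl group on a saturated chain carbon bound to an oxygen on an aromatic ring, gives 720 nM in this assay. Compound 2 thus stands at the higher of the two numbers, and its gap to compound 1 lies well beyond the scatter. Compound 3 `COC(=O)C1=C(C)N=C(C)/C(=C(/O)OC)C1c1cccc(OCc2no[n+]([O-])c2C)c1` differs from compound 2 only by a group of 7 heavy atoms (3 carbon, 2 nitrogen, 2 oxygen; one five-membered aromatic ring with 3 hetero atoms) in place of a group of 6 heavy atoms (3 carbon, 2 nitrogen, 1 oxygen; one five-membered aromatic ring with 3 hetero atoms), on a saturated chain carbon bound to an oxygen on an aromatic ring. For the measured compounds named here, no measured pair shows this change, so no step can be drawn from the data for it. With the rest of the structure kept, compound 3 is expected to stay close to compound 2, with a step of a 1.2-fold lower number from compound 2 to compound 3 (0.08 log units; within the scatter) in this assay, not beyond the scatter. Compound 3 is therefore estimated at 600 nM in this assay, with a range from 200 nM to 2500 nM.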

Compound 3, half-maximal inhibitory concentration: 820 nM
The estimate for compound 3 lay 1.4-fold (0.14 log units) below the measured number, and the stated range covers the measured number.
By their numbers in this assay, from the lowest: compound 1; then compounds 2 and 3 (each within the scatter of the next).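

In this assay, the exchange on a saturated chain carbon bound to an oxygen on an aromatic ring now has its first measured step, a 1.1-fold higher number from compound 2 to compound 3 (0.06 log units; within the scatter), with the group of 7 heavy atoms entering where 4-methyl-1,2,5-oxadiazol-3-yl stood. The two groups share one five-membered aromatic ring with 3 hetero atoms, and the added oxygen leaves compound 2 and compound 3 indistinguishable in this measurement, which shows that this position tolerates this one exchange. No supporting measurement bears on why the number holds.

The compounds shown leave open whether a phenyl ring, an amine or a carboxylic acid at the same place would hold the number as well. They also leave open whether a longer chain between the aromatic ring's oxygen and the five-membered ring would do so.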